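The compounds below may be only part of what the source reports. "The series", "measured", "known", "first", "only" and "open" are said of these compounds alone.

Measured compounds:
- compound 1 `CC(C)=CCOc1ccccc1/C=C/C(=O)c1ccccc1`: 111000 nM
- compound 2 `CC(C)=CCC/C(C)=C/CC/C(C)=C/COc1ccccc1/C=C/C(=O)c1ccccc1`: 141000 nM
- compound 3 `CC(C)=CCC/C(C)=C/COc1cccc(/C=C/C(=O)c2ccccc2)c1`: 81900 nM

In an ADME assay on cells (Peritoneal macrophage cell, Mus musculus, strain BALB/c) for cytotoxicity, read by MTT assay, with a stated time of 24 h (on this read-out higher numbers stand for an effect only at larger amounts of compound and lower numbers for an effect already at smaller amounts), compound 3 gives 81900 nM, which lies within the scatter of the values of both compound 1 and compound 2, so the three cannot be told apart on these numbers.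

The next compound to be measured is compound 4 `CC(C)=CCC/C(C)=C/CC/C(C)=C/COc1cccc(/C=C/C(=O)c2ccccc2)c1`. It differs from compound 3 by one change: 3-methylbut-2-en-1-yl in place of hydrogen on a saturated chain carbon bound to a double-bonded chain carbon. In words, 3-methylbut-2-en-1-yl stands in place of hydrogen on a saturated chain carbon bound to a double-bonded chain carbon.

For the measured compounds named here, only one measured step bears on this change, and it extends the chain at the same kind of carbon, though with 3,7-dimethylocta-2,6-dien-1-yl and on the core of compound 1. Going by the values given here, no shift beyond the scatter is expected in this assay because a 1.3-fold higher number from compound 1 to compound 2 (0.10 log units; within the scatter) is the only such step on record. One step on a different parent is thin evidence, so the range stays wide.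

For compound 4 the estimated value is 100000 nM, with an expected range of 55000 nM to 180000 nM.

The expected step is a 1.2-fold higher number from compound 3 to compound 4 (0.09 log units; within the scatter).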

Compound 4, half-maximal effective concentration: 55100 nM
For compound 4 the middle estimate is 1.8-fold (0.26 log units) above the measured one, and the stated range covers the measured number.
By their numbers in this assay, from the lowest: compounds 4, 3, 1 and 2 (each within the scatter of the next, the first and the last beyond it).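

In this assay the placing of 3-methylbut-2-en-1-yl on a saturated chain carbon bound to a double-bonded chain carbon gives a 1.5-fold lower number from compound 3 to compound 4 (0.17 log units; within the scatter) on this parent, and this adds a second reading of chain extension at this kind of carbon. Set beside a 1.3-fold higher number from compound 1 to compound 2 (0.10 log units; within the scatter) on the other parent, it shows that on both cores the added chain leaves the number within the scatter. The two steps point in opposite directions, so no direction can be assigned to this change, and nothing at hand explains the numbers.

On these data alone, whether an amine or a carboxylic acid on this chain carbon would carry the number beyond the scatter stays open. So does the effect of a longer chain than 3,7-dimethylocta-2,6-dien-1-yl on either core.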